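This account rests on a few compounds, and the source may have more. Where it says the series, first, only, none or still open, it means among the compounds named here.

In an assay for inhibition of Caspase-8 (Homo sapiens) (a higher number here means a weaker inhibitor, a lower number a stronger inhibitor), compound 1 `CCC(C(=O)N[C@@H](CC(=O)O)C(C)=O)n1cc(C(C)(C)C)nc(NCc2nonc2C)c1=O` gives 10000 nM, and compound 2 `CC[C@@H](C(=O)N[C@@H](CC(=O)O)C(=O)CSCc1ccccc1)n1cccc(NC(=O)[C@H](CC(=O)O)NC(C)=O)c1=O` gives 220 nM. Compound 3 `CCCCCCN(C)CNCC(=O)[C@H](CC(=O)O)NC(=O)C(CC)n1cc(C(C)(CC)CC)nc(NCc2nonc2C)c1=O` reaches only a limit of this assay, > 10000 nM, so its inhibition is not resolved as a number; this is the limit of > 10000 nM in this assay, at which 1 of the 3 values shown sits. Compound 4 `CCCCCCN(C)CNCC(=O)[C@H](CC(=O)O)NC(=O)C(CC)n1cc(CC)nc(NCc2nonc2C)c1=O` differs from compound 3 in one place: ethyl in place of 1-ethyl-1-methylpropyl on an aromatic carbon. Going by the values given here, no measured pair shows what such a change does in this assay, and compound 1, which is otherwise closely related, is also weak. Only a small step, if any, beyond the scatter is expected here: a number no higher from compound 3 to compound 4 (the limit leaves the size open). Compound 4 is therefore estimated at 10000 nM, within a range of 3000 nM to 30000 nM.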

Compound 4, half-maximal inhibitory concentration: 9540 nM
Beside the measured number, compound 4's estimate is 1.0-fold (0.02 log units) above it; the range from low to high includes it.
By their numbers in this assay, from the lowest: compound 2; then compounds 4 and 1 (each within the scatter of the next).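

Putting ethyl in place of 1-ethyl-1-methylpropyl on this aromatic carbon gives, in this assay, an at least 1.0-fold lower number from compound 3 to compound 4 (0.02 log units; that floor lies within the scatter). Compound 4 gives 9540 nM, so with ethyl here the assay returns a readable number. The true size of the step stays unknown because the value of compound 3 is a limit and not a number: the limit of > 10000 nM in this assay, at which 1 of the 4 values shown sits.

The compounds shown leave open whether a methyl, an amine or a carboxylic acid on this aromatic carbon would give a lower number. They also leave open how ethyl would behave with a different group on the other side of the core.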